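Methyl for Ethoxy on the Pyrimidine Ring

A few compounds are considered here, and "the series" means these few. Any claim that something is new, unique, unknown or untested is made for them only; others in the source may bear on it.

Compound 1, `CCOc1ncc(-c2nc(C(F)(F)F)sc2N2CCN(C(=O)Cn3ncc4cccnc43)[C@H](C)C2)cn1`: 4.1 nM
Compound 2, `CCOc1ncc(-c2nc(C(F)(F)F)sc2N2CCN(C(=O)Cn3nc(C)nc3C)[C@H](C)C2)cn1`: 7 nM

In a functional assay on CHO-K1 cells for antagonist activity at C-X-C chemokine receptor type 3 (Homo sapiens), read by FLIPR, with a stated time of 10 min (on this read-out lower numbers stand for stronger inhibition and higher numbers for weaker inhibition), compound 1 gives 4.1 nM and compound 2 gives 7 nM. Compound 2 holds the higher of the two numbers, yet the step of a 1.7-fold higher number from compound 1 to compound 2 (0.23 log units; within the scatter) is within the scatter, so the two cannot be told apart. Compound 3, `Cc1ncc(-c2nc(C(F)(F)F)sc2N2CCN(C(=O)Cn3nc(C)nc3C)[C@H](C)C2)cn1`, differs from compound 2 by methyl in place of ethoxy on an aromatic carbon. Among the measured compounds shown here, no measured step bears on this change; the only one available, a 1.7-fold higher number from compound 1 to compound 2 (0.23 log units; within the scatter), concerns another part of the molecule. Compound 3 is therefore expected at 14 nM, with a range of 4 nM to 50 nM. The expected step of a 2.0-fold higher number from compound 2 to compound 3 (0.30 log units; within the scatter) mostly reflects uncertainty.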

Compound 3, half-maximal inhibitory concentration: 19 nM
Compound 3: middle estimate off by 1.4-fold (0.13 log units), on the low side; low and high end bracket the measured number.
By their numbers in this assay, from the lowest: compounds 1 and 2 (each within the scatter of the next); then compound 3.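

Among the compounds shown here, compound 1 and compound 2 both carry the ethoxy group, so this is the first reading at this position, between two ring nitrogen atoms. Methyl in place of ethoxy gives a 2.7-fold higher number from compound 2 to compound 3 (0.43 log units; beyond the scatter) in this assay, a modest change, so this position is not indifferent to its substituent. Nothing available gives a reason for this step.

The compounds shown leave open whether the oxygen or the chain length matters here, which a methoxy or a propyl group on this carbon would separate. They also leave open whether the same change would give a step of similar size on compound 1.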